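The compounds below may be only part of what the source reports. "The series", "measured", "known", "first", "only" and "open" are said of these compounds alone.

Measured so far in a functional assay on SMMC-7721 cells (Homo sapiens) for antiproliferative activity, read by MTT assay, with a stated time of 72 h; a higher number here means a weaker inhibitor, a lower number a stronger inhibitor:

- compound 1 `CN(C(=O)C(C)(C)C)c1ccc2[nH]c(-c3n[nH]c4ccccc34)cc2n1` gives 22200 nM
- compound 2 `CN(C(=O)c1ccccc1)c1ccc2[nH]c(-c3n[nH]c4ccccc34)cc2n1` gives 12500 nM

Within the data shown here, compound 1 has only one measured neighbour, compound 2, and the two lie within the scatter of each other. Compound 3 `CN(C(=O)c1ccc(Cl)cc1)c1ccc2[nH]c(-c3n[nH]c4ccccc34)cc2n1` has not yet been measured. Its difference from compound 1 is 4-chlorophenyl in place of tert-butyl on a carbonyl carbon, which places 4-chlorophenyl on the carbonyl carbon where compound 1 has tert-butyl. Among the measured compounds shown here, only one measured step bears on this change: compound 2 has phenyl in place of tert-butyl on a carbonyl carbon, and a 1.8-fold lower number from compound 1 to compound 2 (0.25 log units; within the scatter) stays within the scatter. For the measured compounds named here, no measured compound carries 4-chlorophenyl, so the effect of that group remains untested. Only a small move toward a lower number in this assay is therefore expected, with nothing clearly beyond the scatter. The estimated step is a 1.7-fold lower number from compound 1 to compound 3 (0.23 log units; within the scatter) for this change. For compound 3 the expected value is 13000 nM, with an estimated range from 6000 nM to 27000 nM.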

Compound 3, half-maximal inhibitory concentration: 2420 nM
Beside the measured number, compound 3's estimate is 5.4-fold (0.73 log units) above it; measured number outside the range, below it.
By their numbers in this assay, from the lowest: compound 3; then compounds 2 and 1 (each within the scatter of the next).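

In this assay, a change on the carbonyl carbon attached to the amide-type nitrogen now moves the number beyond the scatter: 4-chlorophenyl in place of tert-butyl gives a clear drop (a 9.2-fold lower number from compound 1 to compound 3 (0.96 log units; beyond the scatter)). Chloro in place of hydrogen on an aromatic carbon gives a step of its own that also lies beyond the scatter (a 5.2-fold lower number from compound 2 to compound 3 (0.71 log units; beyond the scatter)), whereas phenyl in place of tert-butyl stayed within it (a 1.8-fold lower number from compound 1 to compound 2 (0.25 log units; within the scatter)), so among these compounds the clear gain appears only once chloro is present. Nothing measured here explains why chloro has this effect.

This rests on a single chloro compound. The compounds shown leave open whether a fluoro, methyl or methoxy group in place of the chloro would give a similar step, and whether 3-chlorophenyl would match 4-chlorophenyl.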